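The source may report more compounds than this note shows. Statements on the series, on what has been measured and on what is new or still open speak of the compounds shown alone.

Compound 1 `FC(F)(F)c1ccc(/C=C\c2cc3ccccc3nc2Cl)cc1`: 7940 nM
Compound 2 `Fc1ccc(/C=C\c2cc3ccccc3nc2Cl)cc1`: 35700 nM

Both numbers come from an ADME assay on 184B5 cells (Homo sapiens) for antiproliferative activity, read by sulforhodamine B assay, with a stated time of 72 h; a lower number here means a stronger inhibitor, a higher number a weaker inhibitor. Of the two, compound 2 has the higher number, 35700 nM, which makes it the weaker inhibitor here. Among the measured compounds shown here, the only measured step is a 4.5-fold higher number from compound 1 to compound 2 (0.65 log units; beyond the scatter). That step places fluoro where trifluoromethyl stood on an aromatic carbon, and the double bond is drawn Z on both sides of it.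

The next compound, compound 3 `Fc1ccc(/C=C/c2cc3ccccc3nc2Cl)cc1`, has the same atoms and bonds as compound 2: the two compounds have the same atoms and bonds and differ only in configuration as drawn: 1 of 1 stereo elements differ; a double bond is drawn Z in compound 2 and E in compound 3. Nothing is added or removed, and only the drawn arrangement at the double bond differs. The measured step is the only one available, yet it concerns a different kind of change. For the measured compounds named here, no measured pair compares a Z compound with its E partner, and the data point in neither direction. With no evidence for a shift, the working expectation is no change beyond the scatter, held with wide uncertainty. The expected step is a 1.2-fold lower number from compound 2 to compound 3 (0.08 log units; within the scatter). For compound 3 the estimated value in this assay is 30000 nM, with an expected range of 9000 nM to 90000 nM.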

Compound 3, half-maximal inhibitory concentration: 38500 nM
Beside the measured number, compound 3's estimate is 1.3-fold (0.11 log units) below it, within the range that was stated.
By their numbers in this assay, from the lowest: compound 1; then compounds 2 and 3 (each within the scatter of the next).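

In this assay, swapping the Z double bond for an E double bond while the fluoro group stays in place gives a 1.1-fold higher number from compound 2 to compound 3 (0.03 log units; within the scatter) and so stays within the usual scatter. Among the compounds shown here, the earlier compounds showed only that the group on the aromatic carbon can matter, with (a 4.5-fold higher number from compound 1 to compound 2 (0.65 log units; beyond the scatter)) lying beyond the scatter, whereas this pair adds that the drawn arrangement at the double bond makes no measurable difference here, at least with fluoro on that carbon. This is a clean comparison, since no atom enters or leaves and one thing alone separates the pair: the fact that compounds 2 and 3 differ only in the configuration as drawn

Going by these compounds, whether the same holds with trifluoromethyl on that carbon remains open, since a single pair cannot show whether the lack of difference between Z and E carries over to other groups. Also open, on these data alone, is how the numbers would respond to a different group on that aromatic carbon, such as a methoxy group or an amine, in either arrangement at the double bond.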